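The source may hold more compounds than are shown below. What is called first, only, known or untested is meant among the compounds shown, and "the series" means these compounds.

Of the compounds shown here, two have so far been tested in a functional assay on the whole organism (strain Sprague-Dawley) for inhibition, with Rattus norvegicus as the target, read by paw edema, with stated times of 30 min and 3 h, at a dose of 80 mg/kg by the oral route; a higher number here means more inhibition at the dose given (going by the name of the read-out), a lower number less inhibition. Compound 1 `O=c1c2ccccc2nc(CO[N+](=O)[O-])n1NS(=O)(=O)c1ccccc1` gives 34%. Compound 2 `Cc1ccc(S(=O)(=O)Nn2c(C)nc3ccccc3c2=O)cc1` gives 51.9%, the higher of the two numbers, with compound 1 standing lower by a gap beyond the scatter. Compound 3 `Cc1ccc(S(=O)(=O)Nn2c(CO[N+](=O)[O-])nc3ccccc3c2=O)cc1` differs from compound 2 by nitrooxy in place of hydrogen on a saturated chain carbon bound to an aromatic carbon. Among the measured compounds shown here, no measured pair isolates this change, so compound 3 is expected to move in this assay only by a number 6.9 percentage points lower from compound 2 to compound 3 (within the scatter), a step that may stay within the scatter. Compound 3 is therefore estimated at 45%, within a range from 30% to 60%.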

Compound 3, a percentage reported as inhibition, in the whole organism at one dose (the size of the read-out at that dose, not a potency): 44.3%
Estimate against measurement, compound 3: 0.7 percentage points above; measured number inside the range.
By their numbers in this assay, from the lowest: compound 1; then compounds 3 and 2 (each within the scatter of the next).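

In this assay, nitrooxy in place of hydrogen on a saturated chain carbon bound to an aromatic carbon gives a number 7.6 percentage points lower from compound 2 to compound 3 (within the scatter), so this pair shows no clear effect of the change. Among the compounds shown here, with nitrooxy kept, methyl in place of hydrogen on an aromatic carbon gives a number 10.3 percentage points higher from compound 1 to compound 3 (beyond the scatter), a modest step and the first single change that exceeds the scatter. Nothing available explains either step.

The compounds shown leave open how an amine or a carboxylic acid would behave on that chain carbon. They also leave open whether a group such as methoxy or chlorine on the aromatic carbon would match methyl.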